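From Imidazole to Furan on a Shared Core

This account rests on a few compounds, and the source may have more. Where it says the series, first, only, none or still open, it means among the compounds named here.

In a functional assay on HT-29 cells (Homo sapiens) for cytotoxicity, read by MTT assay, with a stated time of 72 h (a lower number here means a stronger inhibitor, a higher number a weaker inhibitor), compound 1 (`CC(C)(C)c1[nH]cnc1/C=c1\[nH]c(=O)/c(=C/c2cccc(Oc3ccc(F)cc3)c2)[nH]c1=O`) gives 2.1 nM, while compound 2 (`O=c1[nH]/c(=C\c2nc[nH]c2C2CC2)c(=O)[nH]/c1=C\c1cccc(Oc2ccc(F)cc2)c1`) gives 7.4 nM, the higher of the two numbers. Compound 3 (`COCc1ccc(/C=c2\[nH]c(=O)/c(=C/c3cccc(Oc4ccc(F)cc4)c3)[nH]c2=O)o1`) carries 5-(methoxymethyl)furan-2-yl in place of 5-cyclopropyl-1H-imidazol-4-yl on a double-bonded chain carbon bound to an aromatic carbon. For the measured compounds named here, the one measured step that bears on this is a 3.5-fold higher number from compound 1 to compound 2 (0.55 log units; beyond the scatter), a modest change that exchanged only tert-butyl for cyclopropyl. Neither measured compound carries a furan, so the guidance is thin. A similarly modest move to a higher number is expected: a 3.4-fold higher number from compound 2 to compound 3 (0.53 log units; beyond the scatter). Compound 3 is estimated at 25 nM, with a range of 5 nM to 120 nM.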

Compound 3, half-maximal inhibitory concentration: 7 nM
Beside the measured number, compound 3's estimate is 3.6-fold (0.55 log units) above it; the measured number falls inside the stated range.
By their numbers in this assay, from the lowest: compound 1; then compounds 3 and 2 (each within the scatter of the next).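

In this assay the imidazole can give way to a furan at this place: 5-(methoxymethyl)furan-2-yl, with 0 hydrogen-bond donors, replaces 5-cyclopropyl-1H-imidazol-4-yl with a 1.1-fold lower number from compound 2 to compound 3 (0.02 log units; within the scatter) and so shows no loss. Set against 5-(tert-butyl)-1H-imidazol-4-yl, the same furan gives a 3.3-fold higher number from compound 1 to compound 3 (0.52 log units; beyond the scatter) and leaves compound 1 with the lowest number of the three. Nothing measured here explains either step.

On these data alone, the furan ring and its methoxymethyl group enter together, and their separate shares remain unknown. Also open, as far as these compounds go, is whether an amine or a carboxylic acid in place of methoxymethyl would keep the number.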